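This account rests on a few compounds, and the source may have more. Where it says the series, first, only, none or still open, it means among the compounds named here.

Measured compounds:
compound 1 `COc1cc(-c2nnc(SCc3cccc(Br)c3)o2)ccc1O` — 48100 nM
compound 2 `COc1cc(-c2nnc(SCc3ccc(C)cc3)o2)ccc1O` — 6210 nM
compound 3 `COc1cc(-c2nnc(SCc3ccccc3F)o2)ccc1O` — 5790 nM

In a functional assay on cells (T-cell, Mus musculus, strain BALB/c) for inhibition, read by MTT assay, with stated times of 24 h and 72 h (on this read-out lower numbers stand for stronger inhibition and higher numbers for weaker inhibition), compound 3 has the lowest of the three numbers, though compound 2 sits within the scatter of it a 1.1-fold lower number from compound 2 to compound 3 (0.03 log units; within the scatter), while compound 1 lies well above an 8.3-fold lower number from compound 1 to compound 3 (0.92 log units; beyond the scatter). Compound 4 `COc1cc(-c2nnc(SCc3ccc(Cl)cc3)o2)ccc1O` differs from compound 3 in one place: 4-chlorophenyl in place of 2-fluorophenyl on a saturated chain carbon bound to a sulfur. Going by the values given here, two measured steps bear on this change. Replacing the 3-bromophenyl of compound 1 by 4-methylphenyl a 7.7-fold lower number from compound 1 to compound 2 (0.89 log units; beyond the scatter) or by 2-fluorophenyl an 8.3-fold lower number from compound 1 to compound 3 (0.92 log units; beyond the scatter) gave modest drops. Compound 4 carries a halogen, as compound 1 does, so a modest rise in number is expected, a 2.1-fold higher number from compound 3 to compound 4 (0.32 log units; beyond the scatter). Compound 4 is estimated at 12000 nM, within 4000 nM to 40000 nM.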

Compound 4, half-maximal inhibitory concentration: 11100 nM
The estimate for compound 4 lay 1.1-fold (0.03 log units) above the measured number, within the range that was stated.
By their numbers in this assay, from the lowest: compounds 3, 2 and 4 (each within the scatter of the next); then compound 1.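

In this assay a halogen on the ring does not by itself place a compound with compound 1: the 4-chlorophenyl group still gives a clear step down (a 4.3-fold lower number from compound 1 to compound 4 (0.64 log units; beyond the scatter)). Chloro in place of methyl on an aromatic carbon cannot be told apart from no change (a 1.8-fold higher number from compound 2 to compound 4 (0.25 log units; within the scatter)), and the same holds for 4-chlorophenyl in place of 2-fluorophenyl (a 1.9-fold higher number from compound 3 to compound 4 (0.28 log units; within the scatter)). Compound 1, with its 3-bromophenyl, thus remains the only one set apart from the others.

No measurement here explains that gap. From the compounds shown here alone, whether it follows the bromine or its ring position remains open, and a 4-bromophenyl or 3-chlorophenyl group would separate the two.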